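Swapping pyridin-3-yl for 4-methoxyphenyl on a hydrazone core

The compounds below may be only part of what the source reports. "The series", "measured", "known", "first", "only" and "open" are said of these compounds alone.

The study concerns a small set of acylhydrazones built on a shared core, examined in an assay on isolated protein for inhibition of Maltase-glucoamylase (Homo sapiens), with a stated time of 15 min; a lower number here means a stronger inhibitor, a higher number a weaker inhibitor. Compound 1, `O=C(N/N=C/c1cccnc1)c1ccc(-c2nc3ccccc3s2)cc1`, carries a pyridin-3-yl group on the carbon with a double bond to nitrogen. In this assay compound 1 is reported as "not active" (no number reported), so no single number places it on the scale. Compound 2, `COc1ccc(/C=N/NC(=O)c2ccc(-c3nc4ccccc4s3)cc2)cc1OC`, is likewise reported in this assay as "not active" (no number reported). Going by the values given here, compound 3, `COc1cc(/C=N/NC(=O)c2ccc(-c3nc4ccccc4s3)cc2)cc(OC)c1`, is the only member with a measured number, giving 16200 nM in this assay; compound 1 therefore cannot be ranked against it beyond noting that compound 1 returned no number at all.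

Compound 4, `COc1ccc(/C=N/NC(=O)c2ccc(-c3nc4ccccc4s3)cc2)cc1`, has not yet been measured. It differs from compound 1 by 4-methoxyphenyl in place of pyridin-3-yl on a carbon with a double bond to nitrogen. Among the compounds with values here, no measured pair in this set shares this change, so its effect is unknown from the data. Given that compound 2, the 3,4-dimethoxy analogue, returned no number and compound 3 sits at 16200 nM, only a weak result is expected for compound 4 in this assay, and there is a real chance that it too is reported without a number. The estimate for compound 4 in this assay is 30000 nM, within a range of 8000 nM to 100000 nM.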

Compound 4, half-maximal inhibitory concentration: 18300 nM
Beside the measured number, compound 4's estimate is 1.6-fold (0.21 log units) above it; the measured number falls inside the stated range.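

In this assay, the replacement of 3,5-dimethoxyphenyl by 4-methoxyphenyl on a carbon with a double bond to nitrogen gives a 1.1-fold higher number from compound 3 to compound 4 (0.05 log units; within the scatter), so these two groups cannot be told apart at this position. Methoxy groups on the phenyl ring do not by themselves ensure a measured number, however: compound 3 and compound 4 both have one, while compound 2 goes against any such pattern and is reported as "not active" (no number reported), and the swap of pyridin-3-yl for 4-methoxyphenyl cannot be read as a step, as compound 1 is reported as "not active" (no number reported). No measurement is available that would account for these results.

The compounds shown leave open whether any group on this carbon can move the number beyond the scatter, for instance a phenyl ring carrying a hydroxyl group, an amine or a carboxylic acid. They also leave open whether a change elsewhere on the shared core would matter more than the changes seen here.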